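The source may report more compounds than this note shows. Statements on the series, on what has been measured and on what is new or still open speak of the compounds shown alone.

In a physicochemical assay for solubility, at pH 6.8 (a lower number here means a less soluble compound, a higher number a more soluble compound), compound 3 `Cc1nc2c(C#N)c(C)c(-c3ccccc3)c(N3CC[C@H](N(C)C)C3)n2n1` gives 376 ug/mL, the higher of the two actual numbers, while compound 1 `CCN(CC)CCNc1c(-c2ccccc2)c(C)c(C#N)c2nc(C(C)(C)C)nn12` gives 2 ug/mL. Compound 2 `Cc1c(-c2ccccc2)c(N2CC[C@H](N(C)C)C2)n2nc(C(C)(C)COCc3ccccc3)nc2c1C#N` reads < 3 ug/mL, which is a limit of the assay and not a number. Compound 4 `CCCCc1nc2c(C#N)c(C)c(-c3ccccc3)c(N3CC[C@H](N(C)C)C3)n2n1` differs from compound 3 by propyl in place of hydrogen on a saturated chain carbon bound to an aromatic carbon, which also reads as methyl to butyl. Among the compounds with values here, the only measured step that bears on this is an at least 120-fold higher number from compound 2 to compound 3 (2.09 log units; beyond the scatter), large and beyond the scatter, and it put methyl in place of a much larger group. Going from methyl to butyl is a smaller change in the reverse direction, so a moderate fall in this assay, beyond the scatter, is expected. The expected step is a 6.3-fold lower number from compound 3 to compound 4 (0.80 log units; beyond the scatter). For compound 4 the estimated value is 60 ug/mL, within an expected range of 12 ug/mL to 250 ug/mL.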

Compound 4, solubility: 33 ug/mL
Compound 4: the middle estimate sits 1.8-fold (0.26 log units) above what was measured; the measured number falls inside the stated range.
By their numbers in this assay, from the lowest: compound 1; then compound 4; then compound 3.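

In this assay, the earlier step changed methyl only to a much larger group, whereas an 11-fold lower number from compound 3 to compound 4 (1.06 log units; beyond the scatter) shows that extending methyl to butyl, a chain with no ring, is already enough for a large fall. Butyl still keeps a clear margin over 1-((benzyloxy)methyl)-1-methylethyl, with an at least 11-fold higher number from compound 2 to compound 4 (1.04 log units; beyond the scatter), so the three groups fall in order at this position. Compound 2 stands at a limit and not a number: the limit of < 3 ug/mL in this assay, at which 1 of the 4 values shown sits.

The compounds shown leave open how the number moves across shorter chains such as ethyl or propyl. They also leave open whether an amine or a hydroxyl at the end of the butyl chain would recover any of the fall.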